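Compound 3 and a Longer Chain

This account rests on a few compounds, and the source may have more. Where it says the series, first, only, none or still open, it means among the compounds named here.

In a functional assay on P388 cells (Mus musculus) for cytotoxicity (on this read-out higher numbers stand for weaker inhibition and lower numbers for stronger inhibition), compound 3 `COc1ccc2cc1Oc1ccc(cc1)C[C@H]1C(=O)N(C)[C@@H](C2)C(=O)N[C@H](C)C(=O)N[C@@H](C)C(=O)N(C)[C@@H](Cc2ccc(C)cc2)C(=O)N[C@@H](C)C(=O)N1C` gives 24 nM and compound 1 `COc1ccc(C[C@H]2C(=O)N[C@@H](C)C(=O)N(C)[C@H]3Cc4ccc(cc4)Oc4cc(ccc4OC)C[C@@H](C(=O)N[C@H](C)C(=O)N[C@@H](CCSC)C(=O)N2C)N(C)C3=O)cc1` gives 20.4 nM, two values within the scatter of each other. Compound 2 `CCCN1C(=O)[C@@H](C)NC(=O)[C@@H]2Cc3ccc(OC)c(c3)Oc3ccc(cc3)C[C@@H](C(=O)N2C)N(C)C(=O)[C@H](C)NC(=O)[C@H](Cc2ccc(OC)cc2)N(C)C(=O)[C@@H]1C` gives 3.98 nM, a lower number, beyond the scatter. Compound 3 thus shares the high end of these numbers with compound 1. Compound 4 `CCCc1ccc(C[C@H]2C(=O)N[C@@H](C)C(=O)N(C)[C@H]3Cc4ccc(cc4)Oc4cc(ccc4OC)C[C@@H](C(=O)N[C@H](C)C(=O)N[C@@H](C)C(=O)N2C)N(C)C3=O)cc1` alters compound 3 in one place: ethyl in place of hydrogen on a saturated chain carbon bound to an aromatic carbon, which turns 4-methylbenzyl into 4-propylbenzyl. Among the compounds with values here, no two measured compounds differ in one place only, so the data offer no direct guide to this change. For this assay, the expected change is small and within the scatter: a 1.3-fold higher number from compound 3 to compound 4 (0.10 log units; within the scatter). The estimated value for compound 4 is 30 nM, with an expected range of 10 nM to 90 nM.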

Compound 4, half-maximal inhibitory concentration: 25.7 nM
Compound 4: middle estimate off by 1.2-fold (0.07 log units), on the high side; measured number inside the range.
By their numbers in this assay, from the lowest: compound 2; then compounds 1, 3 and 4 (each within the scatter of the next).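

In this assay, the change gives a 1.1-fold higher number from compound 3 to compound 4 (0.03 log units; within the scatter) and so leaves the read-out unchanged within the scatter. Within the data shown here, this is the only step here that differs in a single place, and it shows that, on this core, 4-propylbenzyl and 4-methylbenzyl cannot be told apart by this read-out. Nothing measured here speaks to the reason for this.

On these data alone, a longer chain such as butyl, or an amine or a carboxylic acid in place of the propyl, remains open. So does whether ethyl in place of hydrogen would behave alike on another compound.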